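The compounds below may be only part of what the source reports. "The series", "measured", "known", "first", "only" and "open" are said of these compounds alone.

Three compounds have been measured in an ADME assay on NIH3T3 cells (Mus musculus) for cytotoxicity, read by MTT assay, with a stated time of 24 h; on this read-out higher numbers stand for weaker inhibition and lower numbers for stronger inhibition:

- compound 1 `O=C(CSc1nnc(-c2ccncc2)o1)N/N=C/c1ccc(Br)cc1` gives 169000 nM
- compound 2 `O=C(CSc1nnc(-c2ccncc2)o1)N/N=C/c1cc(Br)ccc1O` gives 156000 nM
- compound 3 `O=C(CSc1nnc(-c2ccncc2)o1)N/N=C/c1cc(Cl)cc(Cl)c1O` gives 171000 nM

All three share the same core and differ only in the aromatic group attached to the carbon that carries a double bond to nitrogen. The numbers sit close together: compound 1 stands second highest of the three, with compound 3 nearest a 1.0-fold higher number from compound 1 to compound 3 (0.01 log units; within the scatter) and compound 2 furthest a 1.1-fold lower number from compound 1 to compound 2 (0.03 log units; within the scatter). The remaining pair behaves the same way a 1.1-fold higher number from compound 2 to compound 3 (0.04 log units; within the scatter). None of these swaps moved the read-out beyond what repeated measurements would show on their own.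

Compound 4 `O=C(CSc1nnc(-c2ccncc2)o1)N/N=C/c1cccs1` is not yet measured. It differs from compound 1 in exactly this place: thiophen-2-yl in place of 4-bromophenyl on a carbon with a double bond to nitrogen. Going by the values given here, no measured pair tests a five-membered ring here, so the three steps bear on it only indirectly, by showing that exchanging one aromatic group for another on this carbon has so far left the read-out unchanged. On that basis, no step beyond the scatter is expected in this assay for compound 4, in either direction.

Compound 4 is therefore estimated to give 165000 nM, with a likely range from 85000 nM to 320000 nM. The expected step of a 1.0-fold lower number from compound 1 to compound 4 (0.01 log units; within the scatter) would be within the scatter.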

Compound 4, half-maximal inhibitory concentration: 189000 nM
Compound 4: the middle estimate sits 1.1-fold (0.06 log units) below what was measured; low and high end bracket the measured number.
By their numbers in this assay, from the lowest: compounds 2, 1, 3 and 4 (each within the scatter of the next).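

Thiophen-2-yl is the first group at this position with a five-membered aromatic ring, with sulfur as its hetero atom, and it carries neither a halogen nor the hydroxyl found in compound 2 and compound 3. In this assay the new steps are a 1.1-fold higher number from compound 1 to compound 4 (0.05 log units; within the scatter) and a 1.1-fold higher number from compound 3 to compound 4 (0.04 log units; within the scatter) and a 1.2-fold higher number from compound 2 to compound 4 (0.08 log units; within the scatter) and all of them lie within the scatter, so among these four compounds, neither ring size, nor a halogen, nor that hydroxyl separates the numbers on a carbon with a double bond to nitrogen. Nothing available explains why this read-out stays so flat across these groups.

On these data alone, all four groups at this position are aromatic rings, so what an amine, a carboxylic acid or a longer chain of saturated carbons would do on this carbon remains open. The shared core is also identical in all four compounds, which leaves open whether a change elsewhere in the core would move the read-out beyond the scatter.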